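The source may report more compounds than this note shows. Statements on the series, on what has been measured and on what is new or still open speak of the compounds shown alone.

compound 1 `O=C(CCCCCNC(=S)NN=C(c1ccccn1)c1ccccn1)NO` gives 2870 nM
compound 2 `O=C(CCCCCNC(=S)N/N=C(\c1ccccc1)c1ccccn1)NO` gives 2140 nM
compound 3 `O=C(CCCCCNC(=S)NN=C(c1ccccc1)c1ccccc1)NO` gives 3810 nM

In a functional assay on K562 cells (Homo sapiens) for antiproliferative activity, read by MTT assay (a higher number here means a weaker inhibitor, a lower number a stronger inhibitor), compound 3 gives 3810 nM and stands level with the rest of the series, its number lying within the scatter of both compound 1 and compound 2. The next compound to consider is compound 4 `Cc1ccc(/C(=N/NC(=S)NCCCCCC(=O)NO)c2ccccc2)cc1`, which departs from compound 3 by methyl in place of hydrogen on an aromatic carbon in one place: methyl in place of hydrogen on an aromatic carbon, para to a large group.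

Within the data shown here, no two measured compounds differ in one place only, so the series offers no direct precedent for this change. Among the measured compounds shown here, the only guide is the spread of the three values. Compound 1 at 2870 nM and compound 2 at 2140 nM differ from compound 3 in their aromatic rings, yet both stay within the scatter of it. On that basis, a step beyond the scatter is not expected in either direction, although three compounds make a thin basis for this expectation.

The estimated step of a 1.2-fold lower number from compound 3 to compound 4 (0.06 log units; within the scatter) is expected to stay within the scatter. For compound 4 the expected value is 3300 nM with an estimated range (1600 nM to 6800 nM).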

Compound 4, half-maximal inhibitory concentration: 4340 nM
The estimate for compound 4 lay 1.3-fold (0.12 log units) below the measured number, within the range that was stated.
By their numbers in this assay, from the lowest: compounds 2, 1, 3 and 4 (each within the scatter of the next, the first and the last beyond it).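

In this assay, among these compounds, methyl in place of hydrogen on an aromatic carbon, para to a large group, gives a 1.1-fold higher number from compound 3 to compound 4 (0.06 log units; within the scatter) and so leaves the number level: this position carries the added methyl with no step that stands clear of the scatter. The series also now has its first step beyond the scatter, as 4-methylphenyl in place of pyridin-2-yl on a carbon with a double bond to nitrogen gives a 2.0-fold higher number from compound 2 to compound 4 (0.31 log units; beyond the scatter) and remains a modest change in the number. That pair swaps the ring and adds the methyl in one replacement, so it cannot show how much of the step belongs to each, and nothing at hand explains either step.

Still open, from the compounds shown here alone, is whether an amine, a carboxylic acid or a methoxy group on the same carbon would stay as level with compound 3 as methyl does. Also open, going by these compounds, is whether methyl on a pyridin-2-yl ring would give a step of the same size as it does on the ring of compound 3.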